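A Chloro Group on the Phenyl of Compound 3

A few compounds are considered here, and "the series" means these few. Any claim that something is new, unique, unknown or untested is made for them only; others in the source may bear on it.

In a functional assay on DU-145 cells (Homo sapiens) for cytotoxicity, read by MTT assay, with a stated time of 48 h (a lower number here means a stronger inhibitor, a higher number a weaker inhibitor), compound 1 `COc1ccc(-c2nc3ccccn3c2C(=O)/C=C\Nc2ccc3cc[nH]c3c2)cc1` gives 10700 nM and compound 2 `COc1ccc(-c2nc3ccccn3c2C(=O)/C=C\Nc2ccc3ncccc3c2)cc1` gives 4720 nM. Compound 3 `O=C(/C=C\Nc1cnc2ccccc2c1)c1c(-c2ccccc2)nc2ccccn12` gives 2440 nM, which lies within the scatter of compound 2 and is a lower number than that of compound 1.

Compound 4 `O=C(/C=C\Nc1cnc2ccccc2c1)c1c(-c2ccc(Cl)cc2)nc2ccccn12` differs from compound 3 by chloro in place of hydrogen on an aromatic carbon, the change from phenyl to 4-chlorophenyl. Going by the values given here, no measured step touches that phenyl. The only one available, a 2.3-fold lower number from compound 1 to compound 2 (0.36 log units; beyond the scatter), lies at the amine nitrogen, so it offers a guide to size and none to direction. That step is modest, and a step no larger is expected here, most likely none beyond the scatter in this assay. The estimated step is a 1.1-fold lower number from compound 3 to compound 4 (0.04 log units; within the scatter). The estimate for compound 4 is 2200 nM, with the measurement expected between 900 nM and 5400 nM.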

Compound 4, half-maximal inhibitory concentration: 4170 nM
Beside the measured number, compound 4's estimate is 1.9-fold (0.28 log units) below it, within the range that was stated.
By their numbers in this assay, from the lowest: compounds 3, 4 and 2 (each within the scatter of the next); then compound 1.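

In this assay, going by these compounds alone, the only measured step on the phenyl is a 1.7-fold higher number from compound 3 to compound 4 (0.23 log units; within the scatter), so chloro in place of hydrogen on this aromatic carbon gives no change that can be told from the scatter. On this one pair, then, the position carries a chloro group, a single heavy atom, without a clear shift in the read-out, and the step at this position is smaller than any that would stand beyond the scatter. Nothing in the data shown explains this result.

As far as these compounds go, what stays open is whether an amine, a nitrile or a carboxylic acid on the same aromatic carbon would also stay within the scatter of compound 3 or would move the number beyond it. Also open, from the compounds shown here alone, is whether chloro on another carbon of the phenyl, or alongside a different group on the amine nitrogen, would give an equally small step.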